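A methoxyazetidine amide carried onto a second core

The compounds below may be only part of what the source reports. "The series", "measured", "known", "first", "only" and "open" are said of these compounds alone.

Compound 2 `CCn1c(-c2cnc(C)nc2)nc2c(N[C@H]3CCN(C(=O)C4CC4)C3)ncnc21` and compound 1 `CCn1c(-c2cnc(C)nc2)nc2c(N[C@H]3CCN(C(=O)N4CC(OC)C4)C3)ncnc21` share one core and differ only in the amide. In a physicochemical assay for lipophilicity, read by HPLC (a higher number here means a more lipophilic compound, a lower number a more polar compound), compound 2 gives 0.8 and compound 1 gives 0.7. The change between them is 3-methoxyazetidin-1-yl in place of cyclopropyl on a carbonyl carbon and it made a step of a number 0.10 log units lower from compound 2 to compound 1 (within the scatter). Compound 3 `CCn1c(-c2ccc(C(F)(F)F)nc2)nc2c(O[C@H]3CCN(C(=O)C4CC4)C3)ncnc21` stands on a different core; how the two cores differ is not broken down here. In this assay compound 3 gives 2.3, the highest of the three numbers and beyond the scatter from both compound 2 and compound 1. Compound 4 `CCn1c(-c2ccc(C(F)(F)F)nc2)nc2c(O[C@H]3CCN(C(=O)N4CC(OC)C4)C3)ncnc21` carries the same change onto the core of compound 3: 3-methoxyazetidin-1-yl in place of cyclopropyl on a carbonyl carbon. Because a number 0.10 log units lower from compound 2 to compound 1 (within the scatter) lay within the scatter, a similarly small step is expected, a number 0.10 log units lower from compound 3 to compound 4 (within the scatter). Compound 4 is therefore estimated at 2.2, with a range from 1.9 to 2.5.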

Compound 4, distribution coefficient: 2.1
For compound 4 the middle estimate is 0.10 log units above the measured one; the range from low to high includes it.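

Carried onto the second core, the change to 3-methoxyazetidin-1-yl in place of cyclopropyl on a carbonyl carbon gives in this assay a step of a number 0.20 log units lower from compound 3 to compound 4 (within the scatter) and so, like the step of a number 0.10 log units lower from compound 2 to compound 1 (within the scatter) on the first core, stays within the scatter. This shows the change carrying over between these two cores, but it rests on two pairs only and does not show that the step would stay this small on any other core. No measurement here accounts for the size of either step.

The compounds shown leave open what an azetidine amide would give with an amine, a carboxylic acid or a longer ether chain in place of the methoxy group. Going by these compounds, whether any of these would give a step beyond the scatter remains unknown.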